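This account rests on a few compounds, and the source may have more. Where it says the series, first, only, none or still open, it means among the compounds named here.

Measured compounds:
- compound 1, `COc1cc(-c2cc(/C=C/C(=O)c3ccc(N)cc3)[nH]n2)cc(OC)c1OC`, -38%
- compound 2, `COc1ccc(C(=O)/C=C/c2cc(-c3cc(OC)c(OC)c(OC)c3)n[nH]2)cc1`, 1%
- compound 3, `COc1cc(C(=O)/C=C/c2cc(-c3cc(OC)c(OC)c(OC)c3)n[nH]2)cc(OC)c1OC`, -82%

In a functional assay on T47D cells (Homo sapiens) for cytotoxicity, read by sulforhodamine B assay, with a stated time of 48 h, tested at 10 uM (on this read-out higher numbers stand for a weaker effect at the one concentration tested and lower numbers for a stronger effect), compound 2 gives 1%, the highest of the three numbers; compound 1 gives -38% and compound 3 gives -82%. Compound 4 is `COc1cc(-c2cc(/C=C/C(=O)c3ccc(F)c(F)c3)[nH]n2)cc(OC)c1OC`; it differs from compound 2 in one place: 3,4-difluorophenyl in place of 4-methoxyphenyl on a carbonyl carbon. For the measured compounds named here, the only measured step that touches the same ring, a number 39 percentage points higher from compound 1 to compound 2 (beyond the scatter), was large and beyond the scatter, but no measured pair shows 3,4-difluorophenyl against 4-methoxyphenyl, so the direction for compound 4 is open. A step in this assay of moderate size downward, with wide uncertainty, is expected; the estimated step is a number 21 percentage points lower from compound 2 to compound 4 (beyond the scatter). For compound 4 the expected value is -20%, with a range from -70% to 20%.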

Compound 4, a percentage reported as activity, at one concentration (the size of the read-out at that concentration, not a potency): 9%
The estimate for compound 4 lay 29 percentage points below the measured number; low and high end bracket the measured number.
By their numbers in this assay, from the lowest: compound 3; then compound 1; then compounds 2 and 4 (each within the scatter of the next).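

On the carbonyl carbon, 3,4-difluorophenyl in place of 4-methoxyphenyl gives no readable change in this assay, with a number 8 percentage points higher from compound 2 to compound 4 (within the scatter). The two groups are therefore not told apart here, whereas 4-aminophenyl stands clearly apart from 3,4-difluorophenyl, with a number 47 percentage points higher from compound 1 to compound 4 (beyond the scatter). No available evidence accounts for these results.

Still open, on these data alone, is what a carboxylic acid or a dimethylamino group on that phenyl ring would give. Also open, as far as these compounds go, is whether a single fluorine behaves like the 3,4-difluorophenyl pair.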